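This account rests on a few compounds, and the source may have more. Where it says the series, first, only, none or still open, it means among the compounds named here.

Compound 1 `COc1cc(-c2nn(-c3ccc(NC(=O)Nc4ccc(Cl)c(Cl)c4)cc3)cc2-c2ccncc2)ccc1Cl` gives 3350 nM in a functional assay on UACC-62 cells (Homo sapiens) for antiproliferative activity, read by sulforhodamine B assay, with a stated time of 48 h (a lower number here means a stronger inhibitor, a higher number a weaker inhibitor), compound 2 `COc1cc(-c2nn(-c3ccc(NC(=O)Nc4ccc(Cl)c(C(F)(F)F)c4)cc3)cc2-c2ccncc2)ccc1Cl` gives 1770 nM, and compound 3 `COc1cc(-c2nn(-c3ccc(NC(=O)Nc4cc(C(F)(F)F)cc(C(F)(F)F)c4)cc3)cc2-c2ccncc2)ccc1Cl` gives 1550 nM. Replacing chloro with trifluoromethyl on an aromatic carbon gave a 1.9-fold lower number from compound 1 to compound 2 (0.28 log units; within the scatter). Compound 2 thus stands second highest of the three numbers, with both compound 3 and compound 1 within the scatter of it. Compound 4 `COc1cc(-c2nn(-c3ccc(NC(=O)c4ccc(Cl)c(Cl)c4)cc3)cc2-c2ccncc2)ccc1Cl` differs from compound 2 by 3,4-dichlorophenyl in place of (4-chloro-3-(trifluoromethyl)phenyl)amino on a carbonyl carbon. For the measured compounds named here, no measured step makes a change of this kind, and the only measured step, a 1.9-fold lower number from compound 1 to compound 2 (0.28 log units; within the scatter), lies within the scatter, so no step beyond the scatter is expected in this assay. Compound 4 is therefore estimated at 2500 nM, expected between 800 nM and 8000 nM, an expected step of a 1.4-fold higher number from compound 2 to compound 4 (0.15 log units; within the scatter).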

Compound 4, half-maximal inhibitory concentration: 6340 nM
Estimate against measurement, compound 4: 2.5-fold (0.40 log units) below, within the range that was stated.
By their numbers in this assay, from the lowest: compounds 3, 2, 1 and 4 (each within the scatter of the next, the first and the last beyond it).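

In this assay, for the compounds shown here, the change on the carbonyl carbon gives a 3.6-fold higher number from compound 2 to compound 4 (0.55 log units; beyond the scatter), the only step so far that lies beyond the scatter. With 3,4-dichlorophenyl kept on both sides, removing the amino nitrogen gives a 1.9-fold higher number from compound 1 to compound 4 (0.28 log units; within the scatter), so at this position that removal alone is not resolved from the scatter. Nothing available accounts for either step. The compounds shown leave open how an oxygen or a methylene link on this carbonyl carbon would read, and whether a morpholine on the aromatic ring would shift the value.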